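A few compounds are considered here, and "the series" means these few. Any claim that something is new, unique, unknown or untested is made for them only; others in the source may bear on it.

Compound 1, `CCCCCCCCCCCC[C@@H](O)[C@H]1CC[C@H]([C@H](O)CCCCCCCCCCNC(=O)c2cccs2)O1`: 282 nM
Compound 2, `CCCCCCCCCCCC[C@@H](O)[C@H]1CC[C@H]([C@H](O)CCCCCCCCCCNC(=O)c2ccoc2)O1`: 191 nM

Among the measured compounds shown here, in a functional assay on DMS-114 cells (Homo sapiens) for inhibition, read by colorimetric assay and sulforhodamine B assay, with a stated time of 48 h (on this read-out higher numbers stand for weaker inhibition of growth and lower numbers for stronger inhibition of growth), compound 2 gives the lower of the two numbers, but the only measured step, a 1.5-fold lower number from compound 1 to compound 2 (0.17 log units; within the scatter), lies within the scatter, so compound 1 and compound 2 are not separated. Compound 3, `CCCCCCCCCCCC[C@@H](O)[C@H]1CC[C@H]([C@H](O)CCCCCCCCCCNC(=O)c2ccnn2C)O1`, differs from compound 2 by 1-methyl-1H-pyrazol-5-yl in place of furan-3-yl on a carbonyl carbon. For the measured compounds named here, the one step that bears on this, a 1.5-fold lower number from compound 1 to compound 2 (0.17 log units; within the scatter), also exchanged one five-membered aromatic ring on the carbonyl carbon for another and changed nothing beyond the scatter. For compound 3 the expected step is therefore a 1.2-fold higher number from compound 2 to compound 3 (0.08 log units; within the scatter). Compound 3 is estimated at 230 nM, within 100 nM to 550 nM.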

Compound 3, concentration for 50% growth inhibition: 10 nM
Beside the measured number, compound 3's estimate is 23-fold (1.36 log units) above it, outside the stated range (below it).
By their numbers in this assay, from the lowest: compound 3; then compounds 2 and 1 (each within the scatter of the next).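

In this assay, the group on the carbonyl carbon can matter a great deal: 1-methyl-1H-pyrazol-5-yl brings a 19-fold lower number from compound 2 to compound 3 (1.28 log units; beyond the scatter) and a 28-fold lower number from compound 1 to compound 3 (1.45 log units; beyond the scatter), whereas furan-3-yl and thiophen-2-yl were not separated. Exchanging one five-membered aromatic ring for another at this place is therefore not always without effect. No measurement shown explains these steps. On these data alone, it remains open whether they go with the methyl group, the second ring nitrogen or both; a plain 1H-pyrazol-5-yl or a phenyl ring on the carbonyl carbon would bear on that.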